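The source may report more compounds than this note shows. Statements on the series, on what has been measured and on what is new or still open speak of the compounds shown alone.

Compound 3 `C[C@@]1(O)[C@H](O)[C@@H](CO)O[C@H]1n1cnc2c(N=[N+]=[N-])nc(N)nc21` was tested in an ADME assay on CCRF-CEM cells (Homo sapiens) for cytotoxicity, read by trypan blue exclusion, with a stated time of 6 days; on this read-out lower numbers stand for higher toxicity in this test and higher numbers for lower toxicity in this test. In this assay compound 3 reaches only a limit, > 100000 nM. Two close relatives land at the same point. Compound 1 `CC(C)(C)OC(=O)NOc1nc(N)nc2c1ncn2[C@@H]1O[C@H](CO)[C@@H](O)[C@@]1(C)O` carries a ((tert-butoxycarbonyl)amino)oxy group where compound 3 carries the azido group, and in this assay compound 1 also gives a limit, > 100000 nM. Compound 2 `C[C@@]1(O)[C@H](O)[C@@H](CO)O[C@H]1n1cnc2c(NO)nc(N)nc21` carries a hydroxyamino group there, and in this assay compound 2 likewise gives a limit, > 100000 nM. What ties the three together is the limit of > 100000 nM in this assay, at which 3 of the 3 values shown sit, and so the steps between them stay unreadable: a step that the two limits leave unreadable from compound 1 to compound 2, a step that the two limits leave unreadable from compound 1 to compound 3 and a step that the two limits leave unreadable from compound 2 to compound 3. Compound 4 `C=C(OCC)c1nc(N)nc2c1ncn2[C@@H]1O[C@H](CO)[C@@H](O)[C@@]1(C)O` differs from compound 3 by 1-ethoxyethenyl in place of azido on an aromatic carbon. Within the data shown here, no measured step has a readable size, and every exchange at this position so far has left the value at the limit. The step of a number no higher from compound 3 to compound 4 (the limit leaves the size open) is therefore expected to bring no change beyond the scatter. For compound 4 the estimate in this assay is 100000 nM, within a range of 40000 nM to 300000 nM, most likely reported again only as a limit.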

Compound 4, half-maximal cytotoxic concentration: > 100000 nM
Compound 4 gave a limit, no number (the forecaster's own chance of this, stated with the estimate: 80%); the middle value sits exactly at the limit.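

In this assay compound 4 also gives only a limit of > 100000 nM and so none of the steps linking compound 1, compound 2, compound 3 and compound 4 can be read: the limit of > 100000 nM in this assay, at which 4 of the 4 values shown sit. The compounds shown leave open whether any group at this position brings a measurable toxicity in this test.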